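Cytotoxicity of Three Ether-Linked Thioureas on Hepatoma Cells

The compounds below may be only part of what the source reports. "The series", "measured", "known", "first", "only" and "open" are said of these compounds alone.

compound 1 `NC(=S)Nc1cccc(OCCCCCOc2ccc(F)cc2)c1`: 5000 nM
compound 2 `COc1ccc(OCCCCCOc2cccc(NC(N)=S)c2)cc1`: a limit of the assay, > 50000 nM
compound 3 `NC(=S)Nc1cccc(OCCCCCOc2ccc(-c3ccccc3)cc2)c1`: a limit of the assay, > 50000 nM

In an ADME assay on Ava5 cells (Homo sapiens) for cytotoxicity (on this read-out lower numbers stand for higher toxicity in this test and higher numbers for lower toxicity in this test), compound 1 gives 5000 nM. For compound 2 the assay reports only a limit, > 50000 nM. For compound 3 it likewise reports only a limit, > 50000 nM. For the measured compounds named here, compound 3 therefore stands at the limit of > 50000 nM in this assay, at which 2 of the 3 values shown sit, and compound 1 is the only compound with a number.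

Compound 4 `CCN(CC)c1ccc(OCCCCCOc2cccc(NC(N)=S)c2)cc1` differs from compound 3 by diethylamino in place of phenyl on an aromatic carbon. Going by the values given here, two measured steps bear on this position: an at least 10-fold higher number from compound 1 to compound 2 (1.00 log units; beyond the scatter) and an at least 10-fold higher number from compound 1 to compound 3 (1.00 log units; beyond the scatter). Both exchanges at this carbon moved the read-out from the number of compound 1 up to the limit. The remaining step, a step that the two limits leave unreadable from compound 2 to compound 3, cannot be read because both ends sit at the limit. Since methoxy and phenyl both reach the limit, compound 4 is expected to stay there as well, and the step of a number no higher from compound 3 to compound 4 (the limit leaves the size open) is expected to be none beyond the scatter. Compound 4 is estimated at 50000 nM, within 15000 nM to 150000 nM.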

Compound 4, half-maximal cytotoxic concentration: > 50000 nM
Compound 4: only a limit was reported; the forecaster's own chance of this, stated with the estimate: 70%; the middle value sits exactly at the limit.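

With diethylamino, the rise over compound 1 extends to a group that, unlike phenyl, has no ring and carries a nitrogen: in this assay the change gives an at least 10-fold higher number from compound 1 to compound 4 (1.00 log units; beyond the scatter). The steps among compound 2, compound 3 and compound 4 cannot be read, since each of these compounds has only a limit of the assay. Compound 1, with fluoro, thus remains the only compound with a number, and the rest of the series now sits at one limit: the limit of > 50000 nM in this assay, at which 3 of the 4 values shown sit.

Going by these compounds, how far compound 2, compound 3 and compound 4 lie from one another past that limit stays open, so no order among them can be given. On these data alone, it is also open whether chloro or a plain hydrogen at this carbon would give a number like that of compound 1 or reach the same limit.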